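The source may report more compounds than this note shows. Statements on the series, on what has been measured and on what is new or still open speak of the compounds shown alone.

Of the compounds shown here, three have so far been measured in a functional assay on MIA PaCa-2 cells (Homo sapiens) for inhibition, read by MTT assay, with a stated time of 4 days; a higher number here means a weaker inhibitor, a lower number a stronger inhibitor. Compound 1 (`COc1cc(NC(C)CCCNC(=O)NNC(=O)Nc2ccc(Cl)c(C(F)(F)F)c2)c2ncccc2c1`) gives 18000 nM, the lowest of the three, and its gaps to the other two lie beyond the scatter. Compound 3 (`COc1cc(NC(C)CCCNC(=O)NNC(=O)NCCCC(C)Nc2cc(OC)cc3cccnc23)c2ncccc2c1`) gives 69000 nM, and compound 2 (`COc1ccc(/C(=N/NC(=O)NCCCC(C)Nc2cc(OC)cc3cccnc23)c2ccccc2)cc1`) gives 155000 nM. Compound 4 (`COc1cc(NC(C)CCCNC(=O)NNC(=O)NCCCO)c2ncccc2c1`) has not yet been measured. It differs from compound 1 in one place, where 3-hydroxypropyl stands in place of 4-chloro-3-(trifluoromethyl)phenyl on an amide-type nitrogen: 3-hydroxypropyl in place of 4-chloro-3-(trifluoromethyl)phenyl on an amide-type nitrogen. Among the measured compounds shown here, no measured pair isolates a single change, so the size of this step cannot be read directly from the data. A rise in the number beyond the scatter is nevertheless expected. For the measured compounds named here, compound 1, at 18000 nM, is the only measured compound carrying 4-chloro-3-(trifluoromethyl)phenyl, while compound 3, which lacks it, gives 69000 nM. The expected change is a 4.4-fold higher number from compound 1 to compound 4 (0.65 log units; beyond the scatter). For compound 4 the estimated value is 80000 nM, with an expected range from 25000 nM to 250000 nM.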

Compound 4, half-maximal inhibitory concentration: >= 250000 nM
Compound 4: no number, only a limit; the forecaster's own chance of this, stated with the estimate: 20%; at least 3.1-fold (0.49 log units) between middle value and limit.
By their numbers in this assay, from the lowest: compound 1; then compound 3; then compound 2. At a limit, above all of these: compound 4.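

Among the compounds shown here, the replacement of 4-chloro-3-(trifluoromethyl)phenyl by 3-hydroxypropyl on the amide-type nitrogen gives the first single change that can be read directly, and it is large: an at least 13-fold higher number from compound 1 to compound 4 (1.14 log units; beyond the scatter). In this assay compound 4 gives no number, only a limit of the assay: the limit of >= 250000 nM in this assay, at which 1 of the 4 values shown sits.

For the compounds shown here, at this position, then, the 4-chloro-3-(trifluoromethyl)phenyl group of compound 1 cannot be exchanged for 3-hydroxypropyl without a loss of inhibition, something no earlier pair could show, though the full size of the loss stays unknown.

The compounds shown leave open whether the ring itself or its chloro and trifluoromethyl substituents account for the difference. An unsubstituted phenyl, a 3-aminopropyl chain or a longer hydroxyalkyl chain on the same nitrogen would help to separate these possibilities.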